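The source may hold more compounds than are shown below. What is called first, only, known or untested is meant among the compounds shown, and "the series" means these compounds.

Measured compounds:
compound 1, `CC(C)(C)c1ccc(CNC(=O)NC(=O)CCl)cc1`, 2400 nM
compound 2, `CCCCCc1cccc(NC(=O)NC(=O)CCl)c1`, 3500 nM
compound 3, `CC(C)(C)c1ccc(CNC(=O)CCCCl)cc1`, 69000 nM

The three measured compounds were tested in a functional assay on M21 cells (Homo sapiens) for antiproliferative activity, with a stated time of 48 h; a lower number here means a stronger inhibitor, a higher number a weaker inhibitor. Compound 1 gives 2400 nM and compound 2 gives 3500 nM; these two values lie within the scatter of each other, so no order between them is claimed. The two cores have the same atoms joined differently, and the difference between them is not broken down here. Compound 3 stands apart from both, giving 69000 nM in this assay.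

Compound 3 arises from compound 1 by one change, (3-chloropropyl in place of ((chloromethyl)carbonyl)amino on a carbonyl carbon). That step is large: a 29-fold higher number from compound 1 to compound 3 (1.46 log units; beyond the scatter).

Compound 4, `CCCCCc1cccc(NC(=O)CCCCl)c1`, is not yet measured. It arises from compound 2 by the same change, (3-chloropropyl in place of ((chloromethyl)carbonyl)amino on a carbonyl carbon), made at the same place. Within the data shown here, the only guide to its outcome is the single earlier step from compound 1 to compound 3, so the expectation below rests on one example and is held loosely. Compound 4 is expected to show a step of about a 26-fold higher number from compound 2 to compound 4 (1.41 log units; beyond the scatter) in this assay, because the same change gave a 29-fold higher number from compound 1 to compound 3 (1.46 log units; beyond the scatter). On that basis compound 4 is estimated at 90000 nM, with a likely span from 25000 nM to 300000 nM in this assay.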

Compound 4, half-maximal inhibitory concentration: > 100000 nM
Compound 4: a limit, no number (the forecaster's own chance of this, stated with the estimate: 20%); at least 1.1-fold (0.04 log units) between middle value and limit.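

In this assay compound 4 gives > 100000 nM, and this is a limit of the assay, not a number. Putting 3-chloropropyl in place of ((chloromethyl)carbonyl)amino on a carbonyl carbon therefore weakens the core of compound 2 as well, giving an at least 28-fold higher number from compound 2 to compound 4 (1.45 log units; beyond the scatter), so on both cores shown the change goes in the same direction and the step is large. This shows that the loss carries over from one core to the other, but it does not show that its size is the same on both, and two cores are too few to establish a rule for the series: the same change on two cores in this assay, a 29-fold higher number (1.46 log units; beyond the scatter) from compound 1 to compound 3 and an at least 28-fold higher number (1.45 log units; beyond the scatter) from compound 2 to compound 4; the limit leaves it open whether they differ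

The compounds shown leave open which part of the ((chloromethyl)carbonyl)amino group the large step depends on, as 3-chloropropyl replaces that group whole. Going by these compounds, it also remains open how a bromomethyl or a plain methyl in place of the chloromethyl, or a longer chain on the carbonyl carbon, would read in this assay on either core.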